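Pyridazine in place of methoxypyridine on the amine

The source may hold more compounds than are shown below. What is called first, only, known or untested is meant among the compounds shown, and "the series" means these compounds.

Compound 3 `COc1ccnc(Nc2cc3[nH]c(-c4cccc(C(F)(F)F)c4)nc3cn2)c1` gives 62% in an ADME assay on microsomes from liver (Mus musculus) for metabolic stability, read by LC-MS, with a stated time of 30 min, tested at 0.1 uM; a higher number here means that more of the compound is left, a lower number that less of the compound is left. In this assay compound 1 `FC(F)(F)Oc1ccc(-c2nc3cnc(Nc4ccccn4)cc3[nH]2)cc1` gives 62%, level with compound 3, and compound 2 `COc1cccnc1Nc1cc2[nH]c(-c3cccc(C(F)(F)F)c3)nc2cn1` gives 80%; compound 3 thus sits with compound 1 at the lower end of the three numbers. For the measured compounds named here, the only measured step is a number 18 percentage points lower from compound 2 to compound 3 (beyond the scatter), which shows that shifting the methoxy group on the pendant ring is enough to move the read-out beyond the scatter.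

Compound 4 `FC(F)(F)c1cccc(-c2nc3cnc(Nc4cccnn4)cc3[nH]2)c1` differs from compound 3 by pyridazin-3-yl in place of 4-methoxypyridin-2-yl on a nitrogen on an aromatic ring. Going by the values given here, no measured step covers this exchange; the one step available merely indicates that the pendant ring matters, without pointing to a direction. Compound 4 is therefore expected near 60% (range 40% to 80%). The expected step of a number 2 percentage points lower from compound 3 to compound 4 (within the scatter) lies within the scatter.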

Compound 4, percent of the compound remaining: 51%
Estimate against measurement, compound 4: 9 percentage points above, and the stated range covers the measured number.
By their numbers in this assay, from the lowest: compound 4; then compounds 1 and 3 (each within the scatter of the next); then compound 2.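

On the nitrogen on an aromatic ring, pyridazin-3-yl in place of 4-methoxypyridin-2-yl gives a number 11 percentage points lower from compound 3 to compound 4 (beyond the scatter) in this assay, and in place of 3-methoxypyridin-2-yl it gives a number 29 percentage points lower from compound 2 to compound 4 (beyond the scatter) at the same place. The earlier step compared only two methoxypyridines, whereas these steps show that this ring with 2 hetero atoms and no methoxy group stands beyond the scatter below both. Nothing available bears on the reason for these steps. The change adds a ring nitrogen and removes the methoxy group at once, so their shares remain unseparated. Going by these compounds, a methoxy group or an amine on the pyridazin-3-yl ring remains open.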